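Methyl added to the core of compound 1

The source may hold more compounds than are shown below. What is called first, only, known or untested is meant among the compounds shown, and "the series" means these compounds.

The series is a small set of compounds run in a functional assay on WiDr cells (Homo sapiens) for antiproliferative activity; on this read-out higher numbers stand for weaker inhibition of growth and lower numbers for stronger inhibition of growth. Compound 1 `CC(C)C[C@H]1C[C@@H](Cl)CCO1` returns only a limit of this assay, > 100000 nM, which is a limit and not a number. Compound 2 `Cl[C@H]1CCO[C@@H](c2ccccc2)C1` also returns a limit, > 100000 nM. Compound 3 `O=[N+]([O-])c1ccc([C@H]2C[C@@H](Cl)CCO2)cc1` likewise returns a limit, > 100000 nM. Among the measured compounds shown here, the one single-point change among the measured compounds, a step that the two limits leave unreadable from compound 2 to compound 3, cannot be read because of the limit of > 100000 nM in this assay, at which 3 of the 3 values shown sit. Compound 1 thus has no readable position within the series; all three measured values are the same limit, and nothing orders them.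

Compound 4 `CC(C)C[C@H]1C[C@@H](Cl)C[C@@H](C)O1` differs from compound 1 by methyl in place of hydrogen on a saturated ring carbon. For the measured compounds named here, no measured step bears on this change, and no step has a readable size, so there is no basis for expecting a shift beyond the scatter in this assay. The change is expected to leave compound 4 at the same limit, so the step from compound 1 to compound 4 is estimated as a step that the limit leaves unreadable from compound 1 to compound 4. Compound 4 is accordingly expected to give 200000 nM, within a range from 50000 nM to 1000000 nM. A result reported again only as a limit is expected to be the most likely outcome for compound 4.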

Compound 4, concentration for 50% growth inhibition: > 100000 nM
Compound 4 gave a limit, no number; the forecaster's own chance of this, stated with the estimate: 85%; the middle value is on the limit's open side.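

The methyl change between compound 1 and compound 4 gives no readable step, because both compounds return a limit and not a number: the limit of > 100000 nM in this assay, at which 4 of the 4 values shown sit.

The compounds shown leave open whether any change to the shared core gives growth inhibition that can be read as a number.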